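Compound 1 to compound 3: trifluoromethyl against tert-butyl

The source may report more compounds than this note shows. Statements on the series, on what has been measured and on what is new or still open speak of the compounds shown alone.

In a physicochemical assay for solubility, in phosphate buffer, at pH 7.4 (a higher number here means a more soluble compound, a lower number a less soluble compound), compound 1 (`CCOC(=O)c1c(-c2ccc(C(F)(F)F)cc2)[nH]c2cccc(OC)c2c1=O`) gives 22000 nM. Compound 2 (`CCOC(=O)c1c(-c2ccccc2Cl)[nH]c2cc(OC)ccc2c1=O`) gives 28000 nM, within the scatter of the figure for compound 1, so the two numbers cannot be placed in any order. For the measured compounds named here, compound 1 therefore stands level with the only other measured compound, and these two structures differ in more than one place. Going by the values given here, the series so far offers no measured step for a single change.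

Compound 3 (`CCOC(=O)c1c(-c2ccc(C(C)(C)C)cc2)[nH]c2cccc(OC)c2c1=O`) keeps the core of compound 1 and carries tert-butyl in place of trifluoromethyl on an aromatic carbon, para to a large group: tert-butyl in place of trifluoromethyl on an aromatic carbon. Among the compounds with values here, no measurement yet isolates this exchange, so the expectation remains a judgement with wide margins. A modest step toward lower numbers in this assay is expected, although a result within the scatter of compound 1 would remain plausible. The estimated step is a 1.8-fold lower number from compound 1 to compound 3 (0.26 log units; within the scatter). The estimate for compound 3 is 12000 nM, with an expected range from 4000 nM to 25000 nM.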

Compound 3, solubility: 1000 nM
Beside the measured number, compound 3's estimate is 12-fold (1.08 log units) above it; measured number below the stated range.
By their numbers in this assay, from the lowest: compound 3; then compounds 1 and 2 (each within the scatter of the next).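

In this assay, for the compounds shown here, tert-butyl in place of trifluoromethyl on an aromatic carbon, para to a large group, gives the first step that can be read for a single change: a 22-fold lower number from compound 1 to compound 3 (1.34 log units; beyond the scatter). This step lies beyond the scatter, so the substituent at this position can shift the read-out substantially on the core of compound 1. The two groups match in heavy-atom count, ring content, hydrogen-bond donors and acceptors, and net charge, so those counted features do not separate compound 1 from compound 3, and nothing at hand gives a measured reason for the size of the step.

As far as these compounds go, with one exchange read at this position, it remains open whether the read-out follows a graded trend across substituents or whether tert-butyl stands apart, which an amine, a carboxylic acid or a longer alkyl chain in the same place would help to show. From the compounds shown here alone, it also remains open whether the same exchange would give a step of similar size on a different substitution pattern of the shared core.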